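The source may report more compounds than this note shows. Statements on the series, on what has been measured and on what is new or still open speak of the compounds shown alone.

Compound 1 `Fc1ccc2nc(Nc3nc4ccccc4s3)sc2c1` was run twice in a functional assay on B16-F10 cells (Mus musculus) for cytotoxicity, read by MTT assay, with a stated time of 48 h (a higher number here means a weaker inhibitor, a lower number a stronger inhibitor), and both entries are limits of the assay rather than numbers: > 50000 nM; > 50000 nM (2 entries). For the measured compounds named here, compound 2 `CCOc1ccc2nc(Nc3nc4ccc(F)cc4s3)sc2c1` is the only compound with a measured number here; in this assay compound 2 gives 33200 nM, a weak inhibitor. Compound 3 `Cc1ccc2nc(Nc3nc4ccc(F)cc4s3)sc2c1` differs from compound 2 in one place: methyl in place of ethoxy on an aromatic carbon. Going by the values given here, no step between measured compounds exists to guide this change, so the expectation rests on compound 2 alone. Compound 3 is expected to sit close to compound 2, with a step of a 1.2-fold higher number from compound 2 to compound 3 (0.08 log units; within the scatter) in this assay that stays within the usual scatter. Compound 3 is estimated at 40000 nM, in a range from 15000 nM to 100000 nM.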

Compound 3, half-maximal inhibitory concentration: 29600 nM
Compound 3: the middle estimate sits 1.4-fold (0.13 log units) above what was measured, within the range that was stated.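

For the compounds shown here, the step of a 1.1-fold lower number from compound 2 to compound 3 (0.05 log units; within the scatter) in this assay is the first reading at this position, on an aromatic carbon of the ring that carries the group. It shows that methyl and ethoxy cannot be told apart here: the oxygen and the extra carbons of ethoxy make no difference beyond the scatter in this pair. No measurement shown bears on why the two compounds read alike.

As far as these compounds go, whether an amine or a carboxylic acid at this position would shift the number beyond the scatter stays open. So does whether any group here gives more than weak inhibition.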